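Ring exchange on the shared core: compound 3 to compound 4

A few compounds are considered here, and "the series" means these few. Any claim that something is new, unique, unknown or untested is made for them only; others in the source may bear on it.

Values in a functional assay on HepG2 cells (Homo sapiens) for cytotoxicity, read by sulforhodamine B assay, with a stated time of 48 h; on this read-out lower numbers stand for stronger inhibition and higher numbers for weaker inhibition:
Compound 1 `N#CCn1c(-c2ccco2)nc2ccccc21`: 88100 nM
Compound 2 `S=c1[nH]nc(Cn2c(-c3ccco3)nc3ccccc32)s1`: 47600 nM
Compound 3 `SC1=NNCC(n2c(-c3ccco3)nc3ccccc32)=N1`: 62100 nM

Compound 3 gives 62100 nM. This value stands within the scatter of the other two: a 1.4-fold lower number from compound 1 to compound 3 (0.15 log units; within the scatter), and a 1.3-fold higher number from compound 2 to compound 3 (0.12 log units; within the scatter).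

The next change leads to compound 4 `N=C1N=C(n2c(-c3ccco3)nc3ccccc32)CN1`, on an aromatic nitrogen: a group of 6 heavy atoms (3 carbon, 3 nitrogen; one five-membered non-aromatic ring with 2 hetero atoms) in place of a group of 7 heavy atoms (3 carbon, 3 nitrogen, 1 sulfur; one six-membered non-aromatic ring with 3 hetero atoms), on an aromatic nitrogen. The closest measured exchange is between two ring groups of similar size: a 1.3-fold higher number from compound 2 to compound 3 (0.12 log units; within the scatter). Replacing the group without a ring gave a 1.9-fold lower number from compound 1 to compound 2 (0.27 log units; within the scatter). Among the compounds with values here, no measured step in this small set exceeds the scatter in this assay. None of them involves the five-membered non-aromatic ring with 2 hetero atoms, so the basis for prediction is narrow. No step beyond the scatter and no particular direction are expected.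

The estimated step is a 1.0-fold lower number from compound 3 to compound 4 (0.01 log units; within the scatter). Compound 4 is expected at 60000 nM, with an estimated range from 24000 nM to 125000 nM.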

Compound 4, half-maximal inhibitory concentration: 63500 nM
The estimate for compound 4 lay 1.1-fold (0.02 log units) below the measured number; the range from low to high includes it.
By their numbers in this assay, from the lowest: compounds 2, 3, 4 and 1 (each within the scatter of the next).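

In this assay, exchanging the six-membered non-aromatic ring with 3 hetero atoms for the five-membered non-aromatic ring with 2 hetero atoms gives a 1.0-fold higher number from compound 3 to compound 4 (0.01 log units; within the scatter), so a ring group without sulfur on this aromatic nitrogen stays within the scatter of one that carries sulfur. Set against the other two groups, the new ring gives a 1.3-fold higher number from compound 2 to compound 4 (0.13 log units; within the scatter) and a 1.4-fold lower number from compound 1 to compound 4 (0.14 log units; within the scatter), which extends the flat picture at this position to a third ring type. No measurement on hand accounts for this flatness.

As far as these compounds go, it remains open whether any group on this nitrogen can move the number beyond the scatter, for example a simple amine, a carboxylic acid or a longer chain. The furan-2-yl group is the same in all four compounds, so its contribution cannot be read from this set.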